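The compounds below may be only part of what the source reports. "The series", "measured", "known", "first", "only" and "open" are said of these compounds alone.

Measured in a functional assay on the whole organism with Rattus norvegicus as the target; a lower number here means that less compound is needed, a higher number that more compound is needed for the effect:
compound 1 `CN(C)S(=O)(=O)CCn1c(=N)sc2cc(OC(F)(F)F)ccc21` gives > 10 mg/kg, a limit of the assay.
compound 2 `N=c1sc2cc(OC(F)(F)F)ccc2n1CCS(=O)(=O)O` gives > 10 mg/kg, likewise a limit of the assay.
compound 3 `CCCSCCn1c(=N)sc2cc(OC(F)(F)F)ccc21` gives 2.4 mg/kg.

Among the compounds with values here, compound 3 carries the only number among the three results; the other two sit at the limit (the limit of > 10 mg/kg in this assay, at which 2 of the 3 values shown sit). Compound 4 `CNCCn1c(=N)sc2cc(OC(F)(F)F)ccc21` differs from compound 3 as follows: methylamino in place of propylsulfanyl on a saturated chain carbon, two bonds along the chain from an aromatic nitrogen. Within the data shown here, no measured step exchanges propylsulfanyl for methylamino. Among the measured compounds shown here, the steps that bear on the change are the two in which propylsulfanyl entered at the same place: an at least 4.1-fold lower number from compound 1 to compound 3 (0.61 log units; beyond the scatter) and an at least 4.1-fold lower number from compound 2 to compound 3 (0.61 log units; beyond the scatter). Both show that a group other than propylsulfanyl at this position left the value at the limit. The step between the two limits is unreadable: a step that the two limits leave unreadable from compound 1 to compound 2. Swapping propylsulfanyl out again for methylamino is therefore expected to raise the number in this assay, with a fair chance that only a limit is reported. Compound 4 is estimated at 8 mg/kg, with a range from 2.5 mg/kg to 30 mg/kg. This corresponds to an expected step of a 3.3-fold higher number from compound 3 to compound 4 (0.52 log units; beyond the scatter).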

Compound 4, dose for half-maximal effect: > 10 mg/kg
Compound 4: a limit, no number; the forecaster's own chance of this, stated with the estimate: 40%; middle value at least 1.2-fold (0.09 log units) from the limit.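

In this assay, exchanging propylsulfanyl for methylamino on the saturated chain carbon gives an at least 4.1-fold higher number from compound 3 to compound 4 (0.61 log units; beyond the scatter). Within the data shown here, the loss at this position is therefore no longer seen only with the sulfonyl-bearing groups of compound 1 and compound 2, and compound 3 remains the only compound of the four with a number. The steps from compound 1 and compound 2 to compound 4 cannot be read, as all three values are limits and not numbers: the limit of > 10 mg/kg in this assay, at which 3 of the 4 values shown sit.

From the compounds shown here alone, how far the true value of compound 4 lies past its limit stays open. Also open, going by these compounds, is whether the number at this position depends on the sulfur or on the chain, which a propoxy group, a propylamino group or a butylsulfanyl group in the same place would help to separate.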